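Para-trifluoromethyl on the phenyl ring of compound 1

The compounds below may be only part of what the source reports. "The series", "measured", "known", "first", "only" and "open" are said of these compounds alone.

Compound 1 `Cc1c(C(C)C)c(=O)on1C(=O)N1CCC(c2ccccc2)CC1` was tested in an assay (strain Wistar) for inhibition of Hormone-sensitive lipase (Rattus norvegicus), read by spectrophotometry (on this read-out lower numbers stand for stronger inhibition and higher numbers for weaker inhibition), where compound 1 gives 12 nM. Going by the values given here, its only measured relative is compound 2 `Cc1c(CC(C)C)c(=O)on1C(=O)N1CCC(c2ccccc2)CC1`, which differs by isobutyl in place of isopropyl on an aromatic carbon; in this assay compound 2 gives 10 nM. The step of a 1.2-fold lower number from compound 1 to compound 2 (0.08 log units; within the scatter) is the only one on record, and it places compound 1 as the higher of the two numbers, though the two values sit within the scatter of each other.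

Compound 3 `Cc1c(C(C)C)c(=O)on1C(=O)N1CCC(c2ccc(C(F)(F)F)cc2)CC1` has not been measured. It differs from compound 1 by trifluoromethyl in place of hydrogen on an aromatic carbon. Among the compounds with values here, no measured step touches this part of the molecule, so the one known step gives no direct guidance; it only shows that a small change elsewhere left the number essentially unmoved. With nothing to argue for a shift in either direction, compound 3 is expected to stay close to compound 1, and the step of a 1.2-fold lower number from compound 1 to compound 3 (0.08 log units; within the scatter) is estimated to lie within the scatter. The value of compound 3 in this assay is therefore estimated at 10 nM, with a range from 3 nM to 40 nM.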

Compound 3, half-maximal inhibitory concentration: 160 nM
Compound 3: middle estimate off by 16-fold (1.20 log units), on the low side, outside the stated range (above it).
By their numbers in this assay, from the lowest: compounds 2 and 1 (each within the scatter of the next); then compound 3.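

In this assay this change gives a 13-fold higher number from compound 1 to compound 3 (1.12 log units; beyond the scatter) and so is a large step beyond the scatter, which shows that the number responds to what is placed on this carbon of the six-membered aromatic ring, para to a large group. Going by these compounds alone, the only earlier step, a 1.2-fold lower number from compound 1 to compound 2 (0.08 log units; within the scatter) within the scatter, concerned another place in the molecule and gave no sign of this sensitivity; trifluoromethyl in place of hydrogen is the first change on record to move the number clearly, and it moves it towards weaker inhibition. No measurement at hand accounts for this rise in the number.

The compounds shown leave open whether the weaker inhibition belongs to trifluoromethyl alone or would also follow from a single fluorine atom, a methyl group or a methoxy group on the same carbon. They also leave open whether the same replacement would raise the number by a similar amount on compound 2, with its isobutyl group, and whether trifluoromethyl on another carbon of that ring would do the same.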